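Removing a Fluoro Group From a Compound Without Measurable Effect

The source may hold more compounds than are shown below. What is called first, only, known or untested is meant among the compounds shown, and "the series" means these compounds.

Compound 1 `COC(=O)[C@H](COC(=O)/C=C/c1ccc(F)cc1)NC(=O)/C=C/c1ccc(F)cc1`: 21.1%
Compound 2 `COC(=O)[C@H](COC(=O)/C=C/c1ccccc1)NC(=O)/C=C/c1ccccc1`: 16.8%
Compound 3 `COC(=O)c1coc(/C=C/c2ccc(F)cc2)n1`: 102%

All three numbers come from an ADME assay on Vero cells (Chlorocebus sabaeus) for cytotoxicity, read by WST assay, tested at 50 ug/mL; on this read-out higher numbers stand for a weaker effect at the one concentration tested and lower numbers for a stronger effect. Compound 1 and compound 2 give values that lie within the scatter of each other, so neither can be called the stronger. Compound 3 stands highest of the three, beyond the scatter above both, which means that at the tested concentration it shows essentially no effect on the cells.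

Compound 4 `COC(=O)c1coc(/C=C/c2ccccc2)n1` has not yet been measured. It differs from compound 3 by hydrogen in place of fluoro on an aromatic carbon. Among the compounds with values here, no measured pair shows this single change on its own. In this assay, the step of a number 4 percentage points lower from compound 3 to compound 4 (within the scatter) is expected to be none beyond the scatter. Compound 4 is therefore expected to give about 98%, with a range from 85% to 110%.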

Compound 4, a percentage reported as activity, at one concentration (the size of the read-out at that concentration, not a potency): 99.6%
Compound 4: middle estimate off by 1.6 percentage points, on the low side; low and high end bracket the measured number.
By their numbers in this assay, from the lowest: compounds 2 and 1 (each within the scatter of the next); then compounds 4 and 3 (each within the scatter of the next).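

In this assay, putting hydrogen in place of fluoro on an aromatic carbon, para to a large group, gives a number 2.4 percentage points lower from compound 3 to compound 4 (within the scatter), the first direct view of this single change. On this core, then, the fluoro is not needed for the cells to show essentially no effect at the one concentration tested. Nothing shown gives a reason for this result. Open, as far as these compounds go, is whether a larger group at this position, such as methoxy or an amine, would behave the same way. Also open, from the compounds shown here alone, is what a carboxylic acid would do in place of the methyl ester.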